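Thiophene in Place of Tolyl on a Sulfonamide Cap

This account rests on a few compounds, and the source may have more. Where it says the series, first, only, none or still open, it means among the compounds named here.

Compound 1, `CCCCCCCCCCCCCCNC(=O)[C@@H](NC(=O)c1cc2ccccc2o1)[C@@H](C)O`, gives 23400 nM in a functional assay on HepG2 cells (Homo sapiens) for cytotoxicity, read by MTT assay, with a stated time of 48 h; on this read-out lower numbers stand for stronger inhibition and higher numbers for weaker inhibition.
Compound 2, `CCCCCCCCCCCCCCNC(=O)[C@@H](NS(=O)(=O)c1ccc(C)cc1)[C@@H](C)O`, gives 10900 nM in this assay.

Among these two numbers compound 2 stands lowest; its nearest neighbour is compound 1, and the step between them, a 2.1-fold lower number from compound 1 to compound 2 (0.33 log units; beyond the scatter), is modest though beyond the usual scatter. Compound 3, `CCCCCCCCCCCCCCNC(=O)[C@@H](NS(=O)(=O)c1cccs1)[C@@H](C)O`, keeps the long chain, the amide and the sulfonamide of compound 2 and differs only in the ring on the sulfonyl sulfur: thiophen-2-yl in place of 4-methylphenyl on a sulfonyl sulfur.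

For the measured compounds named here, the only measured step, a 2.1-fold lower number from compound 1 to compound 2 (0.33 log units; beyond the scatter), exchanged the entire group on the amine nitrogen, a carbonyl-linked bicyclic ring for a sulfonyl-linked methylated benzene. It bears on compound 3 only loosely, since the sulfonyl link is retained and just the ring attached to it is exchanged. Going by the values given here, no measured pair shows what such a ring exchange does, so the expectation is a step no larger than the scatter in either direction. For compound 3 the estimated value in this assay is 12000 nM, with a range from 5000 nM to 30000 nM, which means an expected step of a 1.1-fold higher number from compound 2 to compound 3 (0.04 log units; within the scatter).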

Compound 3, half-maximal inhibitory concentration: 21600 nM
Estimate against measurement, compound 3: 1.8-fold (0.26 log units) below; the measured number falls inside the stated range.
By their numbers in this assay, from the lowest: compounds 2, 3 and 1 (each within the scatter of the next, the first and the last beyond it).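

In this assay, for the compounds shown here, the exchange of 4-methylphenyl for thiophen-2-yl gives the first measured ring change on a sulfonyl sulfur, a 2.0-fold higher number from compound 2 to compound 3 (0.30 log units; within the scatter), so replacing a six-membered carbon ring with a five-membered ring holding one sulfur produces no step that can be told apart from repeat-measurement noise. The second comparison, a 1.1-fold lower number from compound 1 to compound 3 (0.03 log units; within the scatter), adds something the earlier pair could not show: compound 3 keeps the sulfonyl link, yet it cannot be separated from compound 1, which carries (1-benzofuran-2-yl)carbonyl, so the sulfonyl link alone does not reliably go with the lower number seen for compound 2. No available measurement explains why these numbers fall as they do.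

Going by these compounds, it remains open whether a group of a different kind on the sulfonyl sulfur, such as a plain methyl group or a benzene ring bearing an amine or a carboxylic acid, would produce a step beyond the scatter. Also open, on these data alone, is how much of the cytotoxicity depends on the long chain shared by all three compounds, which a shorter chain or a longer chain could test.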